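Removal of the second chloro on the core: expected effect

The compounds below may be only part of what the source reports. "The series", "measured", "known", "first", "only" and "open" are said of these compounds alone.

Among the measured compounds shown here, compound 2 `ClCc1ccccc1Cn1cnc2c(Cl)nc(Cl)nc21` is the only member of the series with a number in a functional assay on HT-29 cells (Homo sapiens) for cytotoxicity, read by sulforhodamine B assay, with a stated time of 48 h; a lower number here means a stronger inhibitor of growth, a higher number a weaker inhibitor of growth: in this assay compound 2 gives 420 nM. Compound 1 `ClCc1ccc(Cn2cnc3c(Cl)ncnc32)cc1`, which carries the chloromethyl group on the other position of the benzyl ring and a single chloro on the core, has no result in this assay, where compound 1 stands as "not determined" (no result reported); it therefore gives no guidance. Compound 3 `ClCc1ccccc1Cn1cnc2c(Cl)ncnc21` keeps the benzyl arrangement of compound 2 and differs from it by hydrogen in place of chloro on an aromatic carbon between two ring nitrogen atoms, meta to the remaining chloro group. For the measured compounds named here, no pair of measured compounds shows this change, so its size is not known from the data. The expectation is a modest loss of growth inhibition, likely close to the scatter, with the step from compound 2 to compound 3 expected at a 1.9-fold higher number from compound 2 to compound 3 (0.28 log units; within the scatter). Compound 3 is accordingly estimated at 800 nM, within a range of 250 nM to 3000 nM.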

Compound 3, concentration for 50% growth inhibition: 3540 nM
Compound 3: middle estimate off by 4.4-fold (0.65 log units), on the low side, and the stated range ends below it.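

In this assay the chloro on the aromatic carbon between two ring nitrogen atoms is now shown to count: hydrogen in its place gives an 8.4-fold higher number from compound 2 to compound 3 (0.93 log units; beyond the scatter) and places this position among those that bear on growth inhibition in the series. Among the compounds shown here, the earlier compounds offered no measured pair for this change, so this is the first size available for it, and it rests on one pair with a single benzyl arrangement. Nothing available explains why the change at this position has a step of this size.

From the compounds shown here alone, whether the chloro is specifically required remains open, as an amine, a methoxy group or a nitrile on the same carbon would show whether other groups can take its place. Going by these compounds, whether the step carries over to the benzyl arrangement of compound 1 also remains open: compound 1 stands as "not determined" (no result reported) in this assay and the corresponding step cannot be read.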